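The source may hold more compounds than are shown below. What is called first, only, known or untested is meant among the compounds shown, and "the series" means these compounds.

Compound 1, `O=C(Nc1ccc(Cl)cc1)c1cc([N+](=O)[O-])ccc1Cl`, in an ADME assay on HEK293 cells (Homo sapiens) for inhibition, with a stated time of 72 h (a lower number here means that less compound is needed, a higher number that more compound is needed for the effect), gives a value reported only as a limit, > 25000 nM.
Compound 2, `O=C(O)/C=C/C(=O)Nc1cccc(-c2nc3ccccc3s2)c1`, gives in this assay likewise a limit, > 25000 nM.
Compound 3, `CN(C)CCC(=O)Nc1cccc(-c2nc3ccccc3s2)c1`, gives in this assay a limit as well, > 25000 nM.

Compound 2 therefore stands at the limit of this assay, not at a number, and the two other values shown sit at the same limit. Going by the values given here, the one step between measured compounds that differ in a single place, a step that the two limits leave unreadable from compound 2 to compound 3, cannot be read, since both ends are limits; the evidence behind all of this is the limit of > 25000 nM in this assay, at which 3 of the 3 values shown sit.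

Compound 4, `O=C(Nc1cccc(-c2nc3ccccc3s2)c1)c1cccnc1Cl`, differs from compound 2 by 2-chloropyridin-3-yl in place of 2-carboxyethenyl on a carbonyl carbon. Among the compounds with values here, no measured step bears directly on this change: the only step available starts from compound 2 and is itself unreadable, and the three values shown give no number at all. With compound 2 at the limit, compound 4 is expected to sit near that same limit in this assay, so the step of a number no higher from compound 2 to compound 4 (the limit leaves the size open) is an expectation of no change beyond the scatter rather than a read from data. Compound 4 is estimated at 25000 nM, within a range from 6000 nM to 100000 nM.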

Compound 4, half-maximal effective concentration: > 25000 nM
Compound 4 ended at the assay's limit (the forecaster's own chance of this, stated with the estimate: 70%); the middle value lies on the limit itself.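

The steps from compound 2 and from compound 3 to compound 4 cannot be read, since both ends of each step are limits and not numbers: the limit of > 25000 nM in this assay, at which 4 of the 4 values shown sit.

The compounds shown leave open what number any of them would give in this assay, and so whether 2-chloropyridin-3-yl differs at all from 2-carboxyethenyl or 2-(dimethylamino)ethyl on the carbonyl carbon.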